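Amine substituent on the tetrahydroquinoline series: ethyl to cyclohexylmethyl

The compounds below may be only part of what the source reports. "The series", "measured", "known", "first", "only" and "open" are said of these compounds alone.

Three compounds of this series have numbers in a functional assay on CCRF-CEM cells for antagonist activity at C-X-C chemokine receptor type 4 (Homo sapiens), read by calcium flux, with stated times of 25 min and 90 s; a higher number here means a weaker inhibitor, a lower number a stronger inhibitor. Compound 1 `C[C@@H]1CN(c2cccc3c2C[C@H](CN(C)[C@H]2CCCc4cccnc42)NC3)C[C@H](C)N1` gives 61 nM. Compound 2 `CN(C[C@H]1Cc2c(cccc2N2CCN(Cc3ccccn3)CC2)CN1)[C@H]1CCCc2cccnc21` gives 4.47 nM. Compound 3 `CCN(C[C@H]1Cc2c(cccc2N2CCNCC2)CN1)[C@H]1CCCc2cccnc21` gives 14.8 nM, which stands second highest of the three: compound 2 is the nearest, with a lower number beyond the scatter, and compound 1 is the furthest, with a higher number beyond the scatter. Compounds 2 and 3 differ in more than one place, so their values are only read side by side and not as a single step.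

Compound 4 `c1cnc2c(c1)CCC[C@@H]2N(CC1CCCCC1)C[C@H]1Cc2c(cccc2N2CCNCC2)CN1` has not been measured in this assay. It differs from compound 3 in one place: cyclohexyl in place of methyl on a saturated chain carbon bound to an amine nitrogen. For the measured compounds named here, no measured pair shows this change, so the size of the step is not known from the data. The expectation is a modest weakening, a step from compound 3 to compound 4 of a 2.7-fold higher number from compound 3 to compound 4 (0.43 log units; beyond the scatter) in this assay. For compound 4 the estimate is 40 nM, with a range from 10 nM to 160 nM.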

Compound 4, half-maximal inhibitory concentration: 715 nM
Estimate against measurement, compound 4: 18-fold (1.25 log units) below, outside the stated range (above it).
By their numbers in this assay, from the lowest: compound 2; then compound 3; then compound 1; then compound 4.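

In this assay, the substituent on the amine nitrogen now has its first measured single-change step: cyclohexyl in place of methyl on a saturated chain carbon bound to an amine nitrogen, which reads equally as ethyl to cyclohexylmethyl, gives a 48-fold higher number from compound 3 to compound 4 (1.68 log units; beyond the scatter). This large step shows that the position is sensitive to this change, with compound 4 at 715 nM against compound 3 at 14.8 nM on an otherwise identical structure. No available evidence bears on the origin of this loss.

Still open, as far as these compounds go, is whether the step follows from the ring itself or from the added carbons, a question that a straight hexyl chain or a cyclopropylmethyl group at this position would address. From the compounds shown here alone, the response of this position to an added hydroxyl or carboxylic acid on the ethyl chain is also open.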